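Removal of the ortho methyl on the aryl group

The compounds below may be only part of what the source reports. "The series", "measured", "known", "first", "only" and "open" are said of these compounds alone.

Two compounds of the series have numbers in an assay on isolated protein for agonist activity at Free fatty acid receptor 1 (Homo sapiens); on this read-out higher numbers stand for an effect only at larger amounts of compound and lower numbers for an effect already at smaller amounts. Compound 1, `CC#CC(CC(=O)O)c1ccc(OCc2ccc3nc(-c4ccc(F)cc4)cn3c2)cc1`, gives 623 nM. Compound 2, `CC#CC(CC(=O)O)c1ccc(OCc2ccc3nc(-c4ccc(C)cc4C)cn3c2)cc1`, gives 316 nM. Going by the values given here, compound 2 thus has the lowest of the two numbers; its nearest neighbour is compound 1, and the single step of a 2.0-fold lower number from compound 1 to compound 2 (0.29 log units; within the scatter) is within the scatter, so the two cannot be ordered on this evidence.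

The next compound, compound 3, `CC#CC(CC(=O)O)c1ccc(OCc2ccc3nc(-c4ccc(C)cc4)cn3c2)cc1`, is the subject here. It differs from compound 2 by hydrogen in place of methyl on an aromatic carbon, on an aromatic carbon of the six-membered aromatic ring of carbon only, ortho to a large group and meta to a methyl group. Among the compounds with values here, only the step from compound 1 to compound 2 touches this ring, and it stayed within the scatter; no step in the set removes a methyl alone. A move between the two known values is therefore the plain expectation, with no step beyond the scatter in either direction: the estimated step is a 1.3-fold higher number from compound 2 to compound 3 (0.12 log units; within the scatter). Compound 3 is expected to give 420 nM in this assay, with a range of 150 nM to 1200 nM.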

Compound 3, half-maximal effective concentration: 507 nM
Compound 3: middle estimate off by 1.2-fold (0.08 log units), on the low side, and the stated range covers the measured number.
By their numbers in this assay, from the lowest: compounds 2, 3 and 1 (each within the scatter of the next).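

In this assay, going by these compounds alone, going from 2,4-dimethylphenyl to 4-methylphenyl gives a 1.6-fold higher number from compound 2 to compound 3 (0.21 log units; within the scatter); this is the only step in the set that concerns the methyl alone, and at this place, ortho to a large group, methyl and hydrogen cannot be told apart on these numbers. The step with methyl in place of fluoro on an aromatic carbon, a 1.2-fold lower number from compound 1 to compound 3 (0.09 log units; within the scatter), also stays within the scatter, so no change among compound 1, compound 2 and compound 3 separates them, and the aryl changes shown so far leave the number in the same range. Nothing measured here bears on why these three numbers lie so close together.

Open is whether a different group at the same place, such as chloro, methoxy or a longer chain like ethyl, would give a step beyond the scatter, since the compounds shown carry only methyl or hydrogen there. Equally open, on these data alone, is whether trifluoromethyl or an amine in place of the methyl of the 4-methylphenyl group would separate from compound 3 in this read-out.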